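Replacing the ethoxycarbonyl group of compound 2

The source may report more compounds than this note shows. Statements on the series, on what has been measured and on what is new or still open speak of the compounds shown alone.

Values in a functional assay on B16-F0 cells (Mus musculus) for inhibition, read by CCK-8 assay, with a stated time of 48 h; on this read-out lower numbers stand for stronger inhibition and higher numbers for weaker inhibition:
- compound 1 (`COc1cc(-c2ccnc3cc(-c4ccc(N(C)C)cc4)nn23)cc(OC)c1OC`): 702 nM
- compound 2 (`CCOC(=O)c1ccc(-c2cc3nccc(-c4cc(OC)c(OC)c(OC)c4)n3n2)cc1`): > 10000 nM, a limit of the assay

Compound 2 has no number on this read-out, only the limit > 10000 nM. Compound 3 (`COc1cc(-c2ccnc3cc(-c4ccc(-c5cnn(C)c5)cc4)nn23)cc(OC)c1OC`) carries 1-methyl-1H-pyrazol-4-yl in place of ethoxycarbonyl on an aromatic carbon, para to a large group (1-methyl-1H-pyrazol-4-yl in place of ethoxycarbonyl on an aromatic carbon). Among the measured compounds shown here, one measured step bears on this place: an at least 14-fold higher number from compound 1 to compound 2 (1.15 log units; beyond the scatter), which is large and brought in the same ethoxycarbonyl that now leaves. For the measured compounds named here, no measured compound carries the new group, so the expectation rests on that single step. With ethoxycarbonyl gone, a large step towards lower numbers is expected in this assay, back towards compound 1 at 702 nM. The expected step is an at least 14-fold lower number from compound 2 to compound 3 (1.15 log units; beyond the scatter). For compound 3 the estimate is 700 nM, with an expected range of 100 nM to 5000 nM.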

Compound 3, half-maximal inhibitory concentration: 1240 nM
Compound 3: middle estimate off by 1.8-fold (0.25 log units), on the low side; the range from low to high includes it.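

In this assay, 1-methyl-1H-pyrazol-4-yl in place of ethoxycarbonyl gives an at least 8.0-fold lower number from compound 2 to compound 3 (0.90 log units; beyond the scatter), so the loss seen with ethoxycarbonyl does not extend to every group of similar size at this place. Set against dimethylamino, the same aromatic ring gives a 1.8-fold higher number from compound 1 to compound 3 (0.25 log units; within the scatter), which shows that dimethylamino is not the only group at this place that keeps a value of this order. Compound 2 stands at a limit of the assay, not at a number, so the true size of the step out of it stays open: the limit of > 10000 nM in this assay, at which 1 of the 3 values shown sits.

The compounds shown leave open whether the loss goes with the ester alone or with any carbonyl group, which a carboxylic acid or a primary amide at this place would tell. They also leave open whether the methyl on the pyrazole counts, which the unsubstituted 1H-pyrazol-4-yl would show.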